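The source may report more compounds than this note shows. Statements on the series, on what has been measured and on what is new or still open speak of the compounds shown alone.

Compound 3 `CCCC(Oc1ccc(-n2cc(C#N)cn2)cc1)c1ccc(C(=O)NCCC(=O)O)cc1` carries a cyano group on its five-membered ring. In a functional assay on cells for antagonist activity at Glucagon receptor (Homo sapiens), read by cAMP accumulation, in the presence of a further agent that is not named here (on this read-out higher numbers stand for weaker inhibition and lower numbers for stronger inhibition), compound 3 gives > 50000 nM, which is a limit of the assay and not a number. Compound 1 `CCCC(Oc1ccc(-n2cc(C(=O)N(C)C)cn2)cc1)c1ccc(C(=O)NCCC(=O)O)cc1` has a dimethylcarbamoyl group in that same place. In this assay compound 1 gives > 30000 nM, again a limit rather than a number. The step that the two limits leave unreadable from compound 1 to compound 3 cannot be read because both ends sit at the limit of > 30000 nM in this assay, at which 1 of the 3 values shown sits, and at the limit of > 50000 nM in this assay, at which 1 of the 3 values shown sits. For the measured compounds named here, compound 2 `O=C(O)CCNC(=O)c1ccc(C(Oc2ccc(-n3cc(C(F)(F)F)cn3)cc2)C2CCC2)cc1` differs from compound 3 in more than one place, so no single step links them; in this assay compound 2 gives 3000 nM, a measured number. Compound 4 `CCCC(Oc1ccc(-n2cc(C)cn2)cc1)c1ccc(C(=O)NCCC(=O)O)cc1` arises from compound 3 by methyl in place of cyano on an aromatic carbon. Going by the values given here, no measured step speaks directly to this change, and the one neighbouring step is unreadable, so the expectation rests only on where compound 3 stands, at a limit, and on the measured number of compound 2. For compound 4 the estimated value is 20000 nM, expected to fall between 5000 nM and 60000 nM. The expected step is an at least 2.5-fold lower number from compound 3 to compound 4 (0.39 log units; beyond the scatter), with a real chance that only a limit is reported again.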

Compound 4, antagonist equilibrium constant: 11000 nM
For compound 4 the middle estimate is 1.8-fold (0.26 log units) above the measured one; the measured number falls inside the stated range.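

With methyl on this aromatic carbon of the five-membered ring, the series gains a measured number at this place, which shows that the read-out here responds to the choice of group, something the two limits alone could not show: in this assay the change from cyano to methyl gives an at least 4.5-fold lower number from compound 3 to compound 4 (0.65 log units; beyond the scatter). The change from dimethylcarbamoyl to methyl gives an at least 2.7-fold lower number from compound 1 to compound 4 (0.43 log units; beyond the scatter), so methyl, the smaller group by its count of heavy atoms, stands apart from both earlier groups. The step between compound 1 and compound 3 still cannot be read, and the step from cyano is only a bound because compound 3 gives a limit: the limit of > 50000 nM in this assay, at which 1 of the 4 values shown sits.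

The full size of the step from dimethylcarbamoyl also stays open because compound 1 gives a limit: the limit of > 30000 nM in this assay, at which 1 of the 4 values shown sits. Whether an ethyl group, a chlorine atom, an amine or a carboxylic acid on this aromatic carbon would lower the number further, and what the trifluoromethyl group of compound 2 would give on the core of compound 4, cannot be told from the compounds shown.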